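Swapping a sulfonamide for an amide at a weak inhibitor

This account rests on a few compounds, and the source may have more. Where it says the series, first, only, none or still open, it means among the compounds named here.

Of the compounds shown here, three have been measured in an assay on COS-7 cells for inhibition of patatin-like phospholipase domain-containing protein 2 (Mus musculus); a higher number here means a weaker inhibitor, a lower number a stronger inhibitor. Compound 1 `CCOC(=O)c1cccc(-c2ccc(C)cc2)c1` gives 140000 nM, compound 2 `CCOC(=O)c1cccc(-c2ccc(C(C)=O)cc2)c1` gives 200000 nM, and compound 3 `CCOc1ccc(-c2cccc(S(=O)(=O)NC)c2)cc1` gives 200000 nM. All three numbers are very high, which means each of these compounds is only a feeble inhibitor. Compound 3 shows the same number as compound 2 at the digits reported, and compound 1 lies within the usual scatter of both, so the three cannot be told apart on these data.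

Compound 4 `CCNC(=O)c1cccc(-c2ccc(OCC)cc2)c1` differs from compound 3 in one place: ethylcarbamoyl in place of methylsulfamoyl on an aromatic carbon. Among the compounds with values here, the only measured step, a 1.4-fold higher number from compound 1 to compound 2 (0.15 log units; within the scatter), changes a group on the other aromatic ring and has no direct bearing on the exchange of a methylsulfamoyl group for an ethylcarbamoyl group. Within the data shown here, there is no measured example of this exchange, and the measured compounds give no ground to expect a move in either direction beyond the scatter. Compound 4 is therefore expected to remain a weak inhibitor in this assay, with an estimated 200000 nM and a range of 70000 nM to 600000 nM, so that the expected step of no change at the digits printed from compound 3 to compound 4 (within the scatter) is essentially none.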

Compound 4, half-maximal inhibitory concentration: 90000 nM
Beside the measured number, compound 4's estimate is 2.2-fold (0.35 log units) above it; the range from low to high includes it.
By their numbers in this assay, from the lowest: compounds 4, 1, 2 and 3 (each within the scatter of the next, the first and the last beyond it).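

In this assay, within the data shown here, the exchange of methylsulfamoyl for ethylcarbamoyl gives the first step in this set that lies beyond the scatter: a 2.2-fold lower number from compound 3 to compound 4 (0.35 log units; beyond the scatter). Among these compounds, this shows that the number responds to the group at this position, something the earlier compounds could not show, as their only step involved a different group; the step is modest, however, and compound 4 at 90000 nM remains a weak inhibitor. No measurement at hand accounts for this step.

On these data alone, the exchange alters two things at once, turning the sulfonyl into a carbonyl and the methyl into an ethyl, so it remains open which of the two matters; methylcarbamoyl or ethylsulfamoyl at the same place would separate them. Also open, as far as these compounds go, is how a carboxylic acid, an amine or a longer chain such as butylcarbamoyl would fare here, and whether any group at this position could bring the number far below this weak range.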